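The source may hold more compounds than are shown below. What is called first, only, known or untested is meant among the compounds shown, and "the series" means these compounds.

Measured compounds in a physicochemical assay for solubility; a higher number here means a more soluble compound, a lower number a less soluble compound:

Compound 1 `CNC(=O)c1cc(C(=O)NCCC2CCOCC2)cn(Cc2ccccc2)c1=O` gives >= 127 ug/mL, which is a limit of the assay and not a number.
Compound 2 `CNC(=O)c1cc(C(=O)NC2CC2)c(C)n(Cc2ccccc2)c1=O` gives >= 126 ug/mL, also a limit of the assay.
Compound 3 `CNC(=O)c1cc(C(=O)NC2CC2)cn(CC2CCOCC2)c1=O` gives >= 165 ug/mL, again a limit of the assay.

None of the three measurements is an exact number. Compound 1 sits at a limit, as shown by the limit of >= 127 ug/mL in this assay, at which 1 of the 3 values shown sits, and the other two values are likewise limits, as shown by the limit of >= 126 ug/mL in this assay, at which 1 of the 3 values shown sits, and (the limit of >= 165 ug/mL in this assay, at which 1 of the 3 values shown sits). So compound 1 cannot be placed above or below its neighbours; the three values show only that every compound is soluble to at least the reach of the assay.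

Compound 4 `CCNC(=O)c1cc(C(=O)NC)c(=O)n(Cc2ccccc2)c1` differs from compound 1 in one place: hydrogen in place of oxan-4-yl on a saturated chain carbon, two bonds along the chain from an amide-type nitrogen. Going by the values given here, no measured pair differs in this way, so nothing tells how large such a step is. Given that compound 1 already stands at a limit, the step that the limit leaves unreadable from compound 1 to compound 4 is expected to be none beyond the scatter. Compound 4 is estimated to give 150 ug/mL, within 80 ug/mL to 300 ug/mL, most probably again as a limit.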

Compound 4, solubility: >= 144 ug/mL
Compound 4: no number, only a limit (the forecaster's own chance of this, stated with the estimate: 80%); the middle value does not contradict the limit.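

In this assay, going by these compounds alone, compound 1 and compound 4 each give only a limit of the assay and not a number, and no step between them can be read. The compounds shown leave open how large the change from oxan-4-yl to hydrogen really is, and whether it has any size at all.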